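Changing the Carbonyl Group of Compound 3

This account rests on a few compounds, and the source may have more. Where it says the series, first, only, none or still open, it means among the compounds named here.

Values in a functional assay on cells (Platelet, Homo sapiens) for inhibition; a higher number here means a weaker inhibitor, a lower number a stronger inhibitor:
- Compound 1 (`CCOC(=O)c1ccc(-c2nn(Cc3cccc(OC)c3)c3ccccc23)cc1`) gives 260 nM in this assay
- Compound 2 (`CCOC(=O)c1ccc(-c2nn(-c3ccco3)c3ccccc23)cc1`) gives 340 nM in this assay
- Compound 3 (`CC(C)OC(=O)c1ccc(-c2nn(Cc3ccccc3)c3ccccc23)cc1`) gives > 10000 nM as a limit in this assay
- Compound 4 (`CCCNC(=O)c1ccc(-c2nn(Cc3ccccc3)c3ccccc23)cc1`) has not yet been measured

The result for compound 3 (> 10000 nM) is a limit of the assay and not a number. This compound is the starting point for the next step, which places propylamino in place of isopropoxy on a carbonyl carbon to give compound 4.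

Within the data shown here, only one measured step is available for comparison (a 1.3-fold higher number from compound 1 to compound 2 (0.12 log units; within the scatter)). It is a change of furan-2-yl for 3-methoxybenzyl on an aromatic nitrogen, not a change on the carbonyl carbon, so it bears on the new step only weakly. Among the measured compounds shown here, no measured pair shows what happens when the group on the carbonyl carbon is exchanged, and no measured compound carries propylamino.

The expectation therefore stays close to compound 3 in this assay, with no firm direction and a wide margin. The expected change is small (a number no higher from compound 3 to compound 4 (the limit leaves the size open)), although this is only a rough estimate. Compound 4 is estimated at 10000 nM within an expected range from 2000 nM to 40000 nM. Compound 4 may well be expected to give only a limit.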

Compound 4, half-maximal inhibitory concentration: > 10000 nM
Compound 4: only a limit was reported; the forecaster's own chance of this, stated with the estimate: 65%; the middle value lies on the limit itself.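

In this assay compound 3 and compound 4 both sit at a limit of the assay rather than at a number, so no step between them can be read: the limit of > 10000 nM in this assay, at which 2 of the 4 values shown sit.

The compounds shown leave open how strongly either one inhibits, and whether propylamino in place of isopropoxy on a carbonyl carbon changes inhibition at all.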